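Adding (4-bromophenyl)sulfonyl to compound 3

The source may report more compounds than this note shows. Statements on the series, on what has been measured and on what is new or still open speak of the compounds shown alone.

Values measured in a functional assay on QGY-7703 cells (Homo sapiens) for cytotoxicity, read by MTT assay, with a stated time of 24 h (on this read-out higher numbers stand for weaker inhibition and lower numbers for stronger inhibition), are as follows
- compound 1 `O=C1/C(=C/c2cccnc2)CNC/C1=C\c1ccccc1F` gives 8890 nM as its value
- compound 2 `CC(=O)Nc1ccc(S(=O)(=O)N2C/C(=C\c3cccnc3)C(=O)/C(=C/c3ccccc3F)C2)cc1` gives 9640 nM as its value
- compound 3 `O=C1/C(=C/c2cccnc2)CNC/C1=C\c1ccccc1C(F)(F)F` gives 3800 nM as its value

Compound 3 has the lowest number of the three, and both other values lie beyond the scatter from it. Compound 4 `O=C1/C(=C/c2cccnc2)CN(S(=O)(=O)c2ccc(Br)cc2)C/C1=C\c1ccccc1C(F)(F)F` differs from compound 3 by (4-bromophenyl)sulfonyl in place of hydrogen on an amine nitrogen in a ring and carries (4-bromophenyl)sulfonyl in place of hydrogen on an amine nitrogen in a ring.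

Going by the values given here, the one measured step, a 2.3-fold lower number from compound 1 to compound 3 (0.37 log units; beyond the scatter) for trifluoromethyl in place of fluoro, lies at another place and says nothing direct about this change. Among the compounds with values here, the closest guide is a pair with no step worked out. Compound 1 has the free amine and gives 8890 nM while compound 2 has a different sulfonyl group on that nitrogen and gives 9640 nM in this assay, two values within the scatter of each other. Within the data shown here, no measured compound carries the bromine, so the range stays wide.

No shift beyond the scatter is therefore expected, and the estimated change is a 1.1-fold lower number from compound 3 to compound 4 (0.04 log units; within the scatter) in this assay as a working figure. For compound 4 the expected value is 3500 nM with an estimated range from 1200 nM to 10000 nM in this assay for now.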

Compound 4, half-maximal inhibitory concentration: 5510 nM
Estimate against measurement, compound 4: 1.6-fold (0.20 log units) below; the measured number falls inside the stated range.
By their numbers in this assay, from the lowest: compounds 3, 4, 1 and 2 (each within the scatter of the next, the first and the last beyond it).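

In this assay, going by these compounds alone, (4-bromophenyl)sulfonyl in place of hydrogen on an amine nitrogen in a ring gives a 1.5-fold higher number from compound 3 to compound 4 (0.16 log units; within the scatter) and is the first step read at this position, so the free amine of compound 3 is not needed to keep the value within the scatter. The same holds for the fluoro pair, where compound 1 gives 8890 nM and compound 2 gives 9640 nM as two values within the scatter of each other, and no compound shown goes against this. Nothing measured here accounts for this result.

Within the data shown here, whether the bromine contributes stays open, with no matching compound carrying hydrogen or methoxy in its place. Also open, from the compounds shown here alone, is how this nitrogen behaves with an acetyl or benzyl group instead of a sulfonyl group.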